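Longer alkyl chain on the shared core: compound 3

The compounds below may be only part of what the source reports. "The series", "measured", "known", "first", "only" and "open" are said of these compounds alone.

Measured so far:
compound 1, `c1ccc(CCc2cccc(N3CCNCC3)n2)cc1`: > 300 mg/kg, a limit of the assay
compound 2, `CCCCc1cccc(N2CCNCC2)n1`: 30 mg/kg

In a functional assay on the whole organism with Mus musculus as the target, in the maximal electroshock model, with a stated time of 120 min (on this read-out lower numbers stand for an effect already at smaller amounts and higher numbers for an effect only at larger amounts of compound), compound 2 gives 30 mg/kg, the only number shown. Compound 1 reports only a limit, (the limit of > 300 mg/kg in this assay, at which 1 of the 2 values shown sits). Among the compounds with values here, the one measured step, an at least 10-fold lower number from compound 1 to compound 2 (1.00 log units; beyond the scatter), concerns a different change from the one now at hand. Compound 3 `CCCCCCCCc1cccc(N2CCNCC2)n1` differs from compound 2 by butyl in place of hydrogen on a saturated chain carbon, four bonds along the chain from an aromatic carbon. Within the data shown here, no measured step bears directly on this change, so no step beyond the scatter is expected; compound 3 is expected to give 30 mg/kg, between 10 mg/kg and 100 mg/kg, which is expected to mean no change at the digits printed from compound 2 to compound 3 (within the scatter).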

Compound 3, minimum effective dose: 10 mg/kg
Compound 3: middle estimate off by 3.0-fold (0.48 log units), on the high side; the range from low to high includes it.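

In this assay, butyl in place of hydrogen on a saturated chain carbon, four bonds along the chain from an aromatic carbon, gives a 3.0-fold lower number from compound 2 to compound 3 (0.48 log units; beyond the scatter), so this position accepts further chain length and the number still falls. Hexyl in place of phenyl gives an at least 30-fold lower number from compound 1 to compound 3 (1.47 log units; beyond the scatter), making this the second open alkyl chain with a lower number than the phenyl-bearing chain of compound 1. Compound 1 stands only as a limit: the limit of > 300 mg/kg in this assay, at which 1 of the 3 values shown sits.

As far as these compounds go, whether the fall continues with a longer chain such as decyl remains open. So does the outcome for a chain ending in an amine or a carboxylic acid.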